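From ethyl to butyl on the shared core

A few compounds are considered here, and "the series" means these few. Any claim that something is new, unique, unknown or untested is made for them only; others in the source may bear on it.

In a functional assay on HL-60 cells (Homo sapiens) for cytotoxicity, read by WST assay, with a stated time of 48 h (a higher number here means that more compound is needed for the effect, a lower number that less compound is needed), compound 1 `Clc1ccc(C[C@H]2COC[C@@H]2Cc2ccccc2)cc1Cl` gives 19000 nM as its value. Compound 2 `COc1ccc(C[C@H]2COC[C@@H]2Cc2ccc(Cl)c(Cl)c2)cc1`, with methoxy in place of hydrogen on an aromatic carbon, gives 39000 nM and compound 3 `CCc1ccc(C[C@H]2COC[C@@H]2Cc2ccc(Cl)c(Cl)c2)cc1`, with ethyl in place of that hydrogen, gives 26000 nM on the same read-out. Compound 3 holds the second highest of these three numbers, yet it lies within the scatter of both others. Thus a 1.4-fold higher number from compound 1 to compound 3 (0.14 log units; within the scatter) counts as no real change, and neither does a 1.5-fold lower number from compound 2 to compound 3 (0.18 log units; within the scatter) on this evidence. Only a 2.1-fold higher number from compound 1 to compound 2 (0.31 log units; beyond the scatter) passes the scatter, and only modestly.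

Compound 4 `CCCCc1ccc(C[C@H]2COC[C@@H]2Cc2ccc(Cl)c(Cl)c2)cc1` is still unmeasured. Its difference from compound 3 is ethyl in place of hydrogen on a saturated chain carbon, two bonds along the chain from an aromatic carbon and in words it is ethyl in place of hydrogen on a saturated chain carbon, two bonds along the chain from an aromatic carbon, which turns ethyl into butyl. Among the measured compounds shown here, no measured step makes this change on a chain. The closest is the ethyl step on an aromatic carbon, where a 1.4-fold higher number from compound 1 to compound 3 (0.14 log units; within the scatter) stayed within the scatter. The expected step in this assay is therefore none beyond the scatter, estimated as a 1.1-fold lower number from compound 3 to compound 4 (0.03 log units; within the scatter) here. For compound 4 the estimate is 24000 nM with an expected range from 11000 nM to 50000 nM in repeat measurements.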

Compound 4, half-maximal effective concentration: 23000 nM
Compound 4: the middle estimate sits 1.0-fold (0.02 log units) above what was measured, and the stated range covers the measured number.
By their numbers in this assay, from the lowest: compounds 1, 4, 3 and 2 (each within the scatter of the next, the first and the last beyond it).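

Turning ethyl into butyl makes no real difference in this assay: the result is a 1.1-fold lower number from compound 3 to compound 4 (0.05 log units; within the scatter), so adding ethyl on a saturated chain carbon, two bonds along the chain from an aromatic carbon, leaves no readable mark on the number. Butyl can also be set against the other two groups at the same aromatic carbon, which gives a 1.7-fold lower number from compound 2 to compound 4 (0.23 log units; within the scatter) for butyl in place of methoxy and a 1.2-fold higher number from compound 1 to compound 4 (0.08 log units; within the scatter) for butyl in place of hydrogen, and neither step passes the scatter. Hydrogen, ethyl and butyl therefore cannot be told apart in this assay, so chain length shows no trend across these compounds, while compound 2 remains the one exception, since methoxy in place of hydrogen gives a 2.1-fold higher number from compound 1 to compound 2 (0.31 log units; beyond the scatter).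

Nothing available here offers an explanation for why these numbers stay so close together. Going by these compounds, whether a longer chain such as hexyl, or an amine or a carboxylic acid in the same place, would move the number beyond the scatter stays open.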